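Methoxy to trifluoromethyl on the chlorophenyl arm

The source may report more compounds than this note shows. Statements on the series, on what has been measured and on what is new or still open speak of the compounds shown alone.

Three compounds of the series have numbers in a functional assay on CHO cells for antagonist activity at gastric inhibitory polypeptide receptor (Homo sapiens), read by scintillation counting and cAMP accumulation, with a stated time of 30 min; on this read-out lower numbers stand for stronger inhibition and higher numbers for weaker inhibition. Compound 2 `COc1cc(Cl)cc(-c2cc(-c3ccc4cc(OC)ccc4c3)n([C@@H](C)c3ccc(C(=O)NCCC(=O)O)cc3)n2)c1` gives 5000 nM and stands at the highest of the three numbers. Compound 1 `CCCOc1ccc(-c2cc(-c3cc(Cl)cc(Cl)c3)nn2Cc2ccc(C(=O)NCCC(=O)O)cc2)cc1Cl` gives 3370 nM, the nearest to compound 2 and within the scatter of it, so no order between the two can be stated. Compound 3 `O=C(O)CCNC(=O)c1ccc(Cn2nc(-c3cc(Cl)cc(Cl)c3)cc2-c2ccc3c(OC(F)(F)F)cccc3c2)cc1` gives 1980 nM, the furthest from compound 2 and a gap that lies beyond the scatter. Among the measured compounds shown here, no pair of these three differs in one place only, so no step between measured compounds can be read off, and no measured change resembles the one considered here.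

Compound 4 `COc1ccc2cc(-c3cc(-c4cc(Cl)cc(C(F)(F)F)c4)nn3[C@@H](C)c3ccc(C(=O)NCCC(=O)O)cc3)ccc2c1` has not been measured in this assay. It differs from compound 2 by trifluoromethyl in place of methoxy on an aromatic carbon. For the measured compounds named here, with no comparable step among the measured compounds, the expectation rests on compound 2 alone and carries a wide range. The step from compound 2 to compound 4 is expected to be a 1.7-fold lower number from compound 2 to compound 4 (0.22 log units; within the scatter), a small move toward a lower number that may fall within the scatter. Compound 4 is therefore expected to give about 3000 nM in this assay, with a range from 1000 nM to 9000 nM.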

Compound 4, half-maximal inhibitory concentration: 1340 nM
The estimate for compound 4 lay 2.2-fold (0.35 log units) above the measured number; measured number inside the range.
By their numbers in this assay, from the lowest: compounds 4, 3, 1 and 2 (each within the scatter of the next, the first and the last beyond it).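

In this assay, a 3.7-fold lower number from compound 2 to compound 4 (0.57 log units; beyond the scatter) gives the series its first one-place step, and it lies beyond the scatter. At this place on the ring, meta to a chloro group, methoxy is not needed to hold the number: 3-chloro-5-(trifluoromethyl)phenyl does better than 3-chloro-5-methoxyphenyl, although the entering group has 0 hydrogen-bond acceptors. Nothing available on these compounds accounts for the size of this step.

The compounds shown leave open whether a nitrile, a bromo group or a longer alkoxy chain at this place would lower the number further. Going by these compounds, as this is a single pair, it also remains open whether the same exchange gives a similar step when the rest of the molecule carries other groups.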